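Working notes: aryl exchange on a flat series

The source may report more compounds than this note shows. Statements on the series, on what has been measured and on what is new or still open speak of the compounds shown alone.

In a functional assay on PC-3 cells (Homo sapiens) for cytotoxicity, read by MTT assay, with a stated time of 72 h (a lower number here means a stronger inhibitor, a higher number a weaker inhibitor), compound 1 `O=C(N/N=C/c1ccc([N+](=O)[O-])cc1)Nc1cc2c(Nc3ccc(F)c(Cl)c3)ncnc2cc1O[C@H]1CCOC1` gives 33500 nM, compound 2 `COc1ccc(/C=N/NC(=O)Nc2cc3c(Nc4ccc(F)c(Cl)c4)ncnc3cc2O[C@H]2CCOC2)c(OC)c1OC` gives 25600 nM and compound 3 `COc1cc(/C=N/NC(=O)Nc2cc3c(Nc4ccc(F)c(Cl)c4)ncnc3cc2O[C@H]2CCOC2)cc(OC)c1OC` gives 29600 nM. Compound 3 thus stands within the scatter of both other compounds, and the three values show no meaningful order.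

The next change leads to compound 4 `O=C(N/N=C/c1ccc(O)c(Br)c1)Nc1cc2c(Nc3ccc(F)c(Cl)c3)ncnc2cc1O[C@H]1CCOC1`: 3-bromo-4-hydroxyphenyl in place of 3,4,5-trimethoxyphenyl on a carbon with a double bond to nitrogen. This places 3-bromo-4-hydroxyphenyl in place of 3,4,5-trimethoxyphenyl on a carbon with a double bond to nitrogen. Among the measured compounds shown here, no measured compound carries the entering group, so only exchanges at this same place bear on the change. These are a 1.3-fold lower number from compound 1 to compound 2 (0.12 log units; within the scatter) and a 1.1-fold lower number from compound 1 to compound 3 (0.05 log units; within the scatter), both small.

The exchange that removes or enters 3,4,5-trimethoxyphenyl against another trimethoxyphenyl is also small: a 1.2-fold higher number from compound 2 to compound 3 (0.06 log units; within the scatter). From these steps, no change beyond the scatter is expected in this assay, and no direction can be assigned. The expected step is a 1.1-fold lower number from compound 3 to compound 4 (0.04 log units; within the scatter). Compound 4 is estimated at 27000 nM, with an expected range of 12000 nM to 50000 nM.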

Compound 4, half-maximal inhibitory concentration: 5230 nM
Compound 4: middle estimate off by 5.2-fold (0.71 log units), on the high side, and the stated range ends above it.
By their numbers in this assay, from the lowest: compound 4; then compounds 2, 3 and 1 (each within the scatter of the next).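

In this assay the aryl group on the carbon with a double bond to nitrogen proves able to shift the number: 3-bromo-4-hydroxyphenyl against 3,4,5-trimethoxyphenyl gives a 5.7-fold lower number from compound 3 to compound 4 (0.75 log units; beyond the scatter) and against 2,3,4-trimethoxyphenyl gives a 4.9-fold lower number from compound 2 to compound 4 (0.69 log units; beyond the scatter) and against 4-nitrophenyl gives a 6.4-fold lower number from compound 1 to compound 4 (0.81 log units; beyond the scatter) as its result. The earlier exchanges among those three groups stayed within the scatter, so this range at the position appears only with compound 4. Nothing available explains the step, though the change does swap three hydrogen-bond acceptors without a donor for one acceptor with one donor, and brings in bromine.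

The compounds shown do not separate the contribution of the bromine from that of the hydroxyl. From the compounds shown here alone, how a 3-bromophenyl group, a 4-hydroxyphenyl group or an aryl amine would stand at this place in this assay remains open.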